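Saturating the amide alkene in a cell-growth series

A few compounds are considered here, and "the series" means these few. Any claim that something is new, unique, unknown or untested is made for them only; others in the source may bear on it.

Measured compounds:
compound 1 `C=C(C)C(=O)N(Cc1ccc(OC)c(O)c1)c1cc(OC)c(OC)c(OC)c1` — 200 nM
compound 2 `C/C=C/C(=O)N(Cc1cccc(O)c1)c1cc(OC)c(OC)c(OC)c1` — 6700 nM

In a functional assay on HCT-116 cells (Homo sapiens) for inhibition, read by MTT assay, with a stated time of 48 h (a lower number here means a stronger inhibitor, a higher number a weaker inhibitor), compound 1 gives 200 nM, the lowest number of the two measured. Compound 2 gives 6700 nM, a markedly higher number, well beyond the scatter; since compound 2 differs from compound 1 in more than one place, no single step can be read from that pair.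

Compound 3 `COc1ccc(CN(C(=O)C(C)C)c2cc(OC)c(OC)c(OC)c2)cc1O` has not been measured. It differs from compound 1 in one place only: isopropyl in place of 1-methylethenyl on a carbonyl carbon. Among the measured compounds shown here, no measured pair in this set shows the same change, so the size of its effect is unknown from these numbers alone. A modest weakening is expected in this assay, of the order a 3.0-fold higher number from compound 1 to compound 3 (0.48 log units; beyond the scatter), though a result within the scatter would not be surprising. Compound 3 is therefore estimated at 600 nM, with a range from 150 nM to 3000 nM.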

Compound 3, half-maximal inhibitory concentration: 310 nM
Beside the measured number, compound 3's estimate is 1.9-fold (0.29 log units) above it, within the range that was stated.
By their numbers in this assay, from the lowest: compounds 1 and 3 (each within the scatter of the next); then compound 2.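

In this assay, among the compounds shown here, the change to isopropyl in place of 1-methylethenyl on a carbonyl carbon gives a 1.6-fold higher number from compound 1 to compound 3 (0.19 log units; within the scatter), the first step that can be read at this position. Removing the double bond outside aromatic rings therefore leaves the number within the scatter, and the two compounds cannot be ordered in this assay. No measurement on hand bears on why this change has so small an effect.

Still open, on these data alone, is how far this position allows a change in the group on the carbonyl carbon, for example a longer chain such as n-butyl, or an amine. As far as these compounds go, it also remains open whether the same change gives a step of similar size on other members.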